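The source may report more compounds than this note shows. Statements on the series, on what has been measured and on what is new or still open speak of the compounds shown alone.

Working notes on the series.

Two compounds of the shared core have numbers in a functional assay on CRL2813 cells (Homo sapiens) for cytotoxicity, read by sulforhodamine B assay, with a stated time of 5 days; on this read-out lower numbers stand for stronger inhibition and higher numbers for weaker inhibition. Compound 1 `O=C(Nc1ccccc1Cl)N[C@H]1CC[C@H](Oc2ccc(F)cc2)CC1` gives 9100 nM. Compound 2 `O=C(Nc1ccccc1F)N[C@H]1CC[C@H](Oc2ccc(F)cc2)CC1` gives 17500 nM. Going by the values given here, the one step between them, a 1.9-fold higher number from compound 1 to compound 2 (0.28 log units; within the scatter), is fluoro in place of chloro on an aromatic carbon. Compound 2 thus has the higher of the two numbers, but its gap to compound 1 stays within the scatter, so no order between the two can be claimed.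

Compound 3 `O=C(Nc1ccccc1C(F)(F)F)N[C@H]1CC[C@H](Oc2ccc(F)cc2)CC1` is not yet measured. The change from compound 2 is trifluoromethyl in place of fluoro on an aromatic carbon. Among the compounds with values here, the only measured step that bears on it is the one from compound 1 to compound 2, which was within the scatter, so a further exchange at the same aromatic carbon is expected to give a step of similar size or none beyond the scatter.

The expected step in this assay is a 1.8-fold lower number from compound 2 to compound 3 (0.24 log units; within the scatter). Compound 3 is estimated at 10000 nM, with a range from 4000 nM to 25000 nM.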

Compound 3, half-maximal inhibitory concentration: > 20000 nM
Compound 3: only a limit was reported; the forecaster's own chance of this, stated with the estimate: 10%; middle value at least 2.0-fold (0.30 log units) from the limit.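

In this assay, going by these compounds alone, trifluoromethyl in place of chloro on this aromatic carbon gives an at least 2.1-fold higher number from compound 1 to compound 3 (0.34 log units; beyond the scatter), the first step at this position that clears the scatter. Trifluoromethyl in place of fluoro gives an at least 1.1-fold higher number from compound 2 to compound 3 (0.05 log units; that floor lies within the scatter), so no order can be claimed between these two compounds. The reported value of compound 3 is a limit and not a number: the limit of > 20000 nM in this assay, at which 1 of the 3 values shown sits.

From the compounds shown here alone, how far the true value of compound 3 lies from that limit stays open, so both steps to it remain floors and not sizes. Also open is whether an amine, a methoxy group or a carboxylic acid on this aromatic carbon would give a lower number than any of the three groups shown, which would indicate whether this position can carry stronger inhibition at all.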